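A few compounds are considered here, and "the series" means these few. Any claim that something is new, unique, unknown or untested is made for them only; others in the source may bear on it.

Measured in a functional assay on MCF7 cells (Homo sapiens) for cytotoxicity, read by MTT assay, with a stated time of 72 h; on this read-out higher numbers stand for weaker inhibition and lower numbers for stronger inhibition:
compound 1 `Cc1ccc(-c2ccc([N+](=O)[O-])cc2)n1-c1ccc(-c2nc3ccc(F)cc3s2)cc1`, 2370 nM
compound 2 `COc1cc(-c2ccc(C)n2-c2ccc(-c3nc4ccc(F)cc4s3)cc2)cc(OC)c1OC`, 2360 nM
compound 3 `COc1ccc2nc(-c3ccc(-n4c(C)ccc4-c4ccc([N+](=O)[O-])cc4)cc3)sc2c1`, 4520 nM

Compound 4 `COc1ccc2nc(-c3ccc(-n4c(C)ccc4-c4cc(OC)c(OC)c(OC)c4)cc3)sc2c1` has not yet been measured in this assay. Compound 3 is compound 1 carrying (methoxy in place of fluoro on an aromatic carbon); in this assay that single change gave a 1.9-fold higher number from compound 1 to compound 3 (0.28 log units; within the scatter). Compound 4 is compound 2 carrying the same change, (methoxy in place of fluoro on an aromatic carbon), and the two descriptions of the place match word for word. The difference between the cores of compound 1 and compound 2 is not broken down here; their values in this assay lie within the scatter of each other, so nothing is said about their order. With one earlier instance only, compound 4 is expected to sit a step of about the same size from its parent, a 1.9-fold higher number from compound 2 to compound 4 (0.28 log units; within the scatter), because that change earlier gave a 1.9-fold higher number from compound 1 to compound 3 (0.28 log units; within the scatter). Compound 4 is therefore estimated at 4500 nM, between 2000 nM and 9500 nM.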

Compound 4, half-maximal inhibitory concentration: 1520 nM
Compound 4: middle estimate off by 3.0-fold (0.47 log units), on the high side; the whole stated range lies above it.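

In this assay, replacing 6-fluoro-1,3-benzothiazol-2-yl with 6-methoxy-1,3-benzothiazol-2-yl gives a 1.6-fold lower number from compound 2 to compound 4 (0.19 log units; within the scatter). The step measured on one core does not carry over as a single size to the other: the same change on two cores in this assay, a 1.9-fold higher number (0.28 log units; within the scatter) from compound 1 to compound 3 and a 1.6-fold lower number (0.19 log units; within the scatter) from compound 2 to compound 4, 3.0-fold (0.47 log units) apart, beyond the scatter of two such steps

Each step alone lies within the scatter, so neither gives the change a reliable direction, and two pairs show neither a general rule for the series nor the reason for the gap. The compounds shown leave open how an amine or a carboxylic acid in place of fluoro would read in this assay, and whether a gap of this kind recurs on a third core.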